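Replacing furan-3-yl in compound 3

The source may report more compounds than this note shows. Statements on the series, on what has been measured and on what is new or still open speak of the compounds shown alone.

Values in an ADME assay (liver) for metabolic stability, with Liver microsome (Homo sapiens) as the target, using microsomes and NADPH, with a stated time of 30 min, tested at 1 uM (on this read-out lower numbers stand for slow clearance and higher numbers for fast clearance), are as follows
Compound 1 `Nc1ccc(S(=O)(=O)N2CCN(c3ncc(C(O)(C(F)(F)F)C(F)(F)F)cc3C3CC3)CC2)cn1` gives 38 mL.min-1.g-1 as a number
Compound 2 `Nc1ccc(S(=O)(=O)N2CCN(c3ncc(C(O)(C(F)(F)F)C(F)(F)F)cc3C#CCCO)CC2)cn1` gives < 14 mL.min-1.g-1 as a limit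
Compound 3 `Nc1ccc(S(=O)(=O)N2CCN(c3ncc(C(O)(C(F)(F)F)C(F)(F)F)cc3-c3ccoc3)CC2)cn1` gives < 14 mL.min-1.g-1 as a limit

Compound 3 has no exact number and stands at the limit of < 14 mL.min-1.g-1 in this assay, at which 2 of the 3 values shown sit, on this scale. Compound 4 `CS(=O)(=O)Nc1cccc(-c2cc(C(O)(C(F)(F)F)C(F)(F)F)cnc2N2CCN(S(=O)(=O)c3ccc(N)nc3)CC2)c1` carries 3-(methanesulfonamido)phenyl in place of furan-3-yl on an aromatic carbon. Changes at that same carbon gave an at least 2.7-fold lower number from compound 1 to compound 2 (0.43 log units; beyond the scatter) and an at least 2.7-fold lower number from compound 1 to compound 3 (0.43 log units; beyond the scatter) in this assay while a step that the two limits leave unreadable from compound 2 to compound 3 also stands. None of these steps involves the entering group, so they guide the expectation only loosely. A small upward step is expected, possibly none beyond the scatter. The expected change is an at least 1.0-fold higher number from compound 3 to compound 4 (0.02 log units; that floor lies within the scatter) on this estimate. For compound 4 the estimated value is 15 mL.min-1.g-1 with an expected range from 7 mL.min-1.g-1 to 32 mL.min-1.g-1 in this read-out.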

Compound 4, intrinsic clearance in microsomes: 40 mL.min-1.g-1
Estimate against measurement, compound 4: 2.7-fold (0.43 log units) below; the measured number lies above the stated range.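

In this assay, this carbon does not tolerate every replacement of cyclopropyl equally: 3-(methanesulfonamido)phenyl gives an at least 2.8-fold higher number from compound 3 to compound 4 (0.45 log units; beyond the scatter) and an at least 2.8-fold higher number from compound 2 to compound 4 (0.45 log units; beyond the scatter). Set against the original group, it gives a 1.1-fold higher number from compound 1 to compound 4 (0.02 log units; within the scatter), so the limits seen for compounds 2 and 3 do not extend to compound 4. No measurement shown gives a cause for this rise.

Going by these compounds, it remains open whether the phenyl ring or the methanesulfonamido group accounts for the difference. Plain phenyl, a 3-aminophenyl group or a 3-carboxyphenyl group at this carbon would help to separate the two.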